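Benzyloxy for 4-(dimethylamino)phenyl on the compound 1 amide

The compounds below may be only part of what the source reports. "The series", "measured", "known", "first", "only" and "open" are said of these compounds alone.

Compound 1 `CN(C)c1ccc(C(=O)N[C@@H](CCCCCC(=O)NO)C(=O)NCc2ccccc2)cc1`: 12000 nM
Compound 2 `CN(C)c1ccc(C(=O)N[C@H](CCCCCC(=O)NO)C(=O)NCc2ccccc2)cc1`: 1000 nM
Compound 3 `CC(C)CCNC(=O)C(CCCCCC(=O)NO)NC(=O)c1cccnc1`: 12000 nM

In a functional assay on NFF cells (Homo sapiens) for antiproliferative activity (on this read-out higher numbers stand for weaker inhibition and lower numbers for stronger inhibition), compound 1 gives 12000 nM, level at the digits shown with compound 3, and together with compound 3 it stands at the highest number of the three. Its nearest neighbour by value is compound 3; its furthest is compound 2, which gives 1000 nM, so that there is a 12-fold lower number from compound 1 to compound 2 (1.08 log units; beyond the scatter). That step rests on the fact that compounds 1 and 2 differ only in the configuration as drawn and says nothing about the group on the carbonyl carbon.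

Compound 4 `O=C(CCCCC[C@H](NC(=O)OCc1ccccc1)C(=O)NCc1ccccc1)NO` differs from compound 1 in benzyloxy in place of 4-(dimethylamino)phenyl on a carbonyl carbon. Among the compounds with values here, no measured step shows what happens in this assay when that group is exchanged; the single step on record concerns configuration alone. The expectation for compound 4 is therefore anchored on compound 1, with a wide range to allow for a change in either direction, amounting to a 1.3-fold lower number from compound 1 to compound 4 (0.12 log units; within the scatter). Compound 4 is estimated at 9000 nM, between 2500 nM and 30000 nM.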

Compound 4, half-maximal inhibitory concentration: 1520 nM
Beside the measured number, compound 4's estimate is 5.9-fold (0.77 log units) above it; measured number below the stated range.
By their numbers in this assay, from the lowest: compounds 2 and 4 (each within the scatter of the next); then compounds 1 and 3 (each within the scatter of the next).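

In this assay, the group on the carbonyl carbon now proves to matter: benzyloxy in place of 4-(dimethylamino)phenyl gives a clear shift (a 7.9-fold lower number from compound 1 to compound 4 (0.90 log units; beyond the scatter)), whereas the earlier step concerned configuration alone. The number at this site therefore responds to a change of group as well as to a change of configuration as drawn, even though both groups carry one six-membered aromatic ring of carbon only and the same counts of donors and acceptors. Nothing shown gives a reason for this shift.

On these data alone, it remains open which part of the exchange carries the step, since the oxygen of benzyloxy enters as the dimethylamino group leaves; a plain phenyl or a 4-methoxyphenyl on the same carbonyl carbon would separate the two. As far as these compounds go, the effect of the opposite configuration on compound 4 also remains open.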